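A few compounds are considered here, and "the series" means these few. Any claim that something is new, unique, unknown or untested is made for them only; others in the source may bear on it.

Measured compounds:
Compound 1, `COc1cc2c(Nc3ccc(OCc4cccc(F)c4)c(Cl)c3)ncnc2cc1OCCCCCn1ccnc1[N+](=O)[O-]` — 14400 nM in a functional assay on A549 cells (Homo sapiens) for inhibition, read by sulforhodamine B assay, with a stated time of 72 h; a lower number here means a stronger inhibitor, a higher number a weaker inhibitor.
Compound 2, `COc1cc2c(Nc3ccc(OCc4cccc(F)c4)c(Cl)c3)ncnc2cc1OCCOCCn1ccnc1[N+](=O)[O-]` — 6230 nM.
Compound 3, `COc1cc2c(Nc3cccc(Br)c3)ncnc2cc1OCCCCCn1ccnc1[N+](=O)[O-]` — 8420 nM.

Compound 1 and compound 2 share one core and differ only in the linker to the nitroimidazole: 2-(2-nitro-1H-imidazol-1-yl)ethoxy in place of 3-(2-nitro-1H-imidazol-1-yl)propyl on a saturated chain carbon, two bonds along the chain from an oxygen on an aromatic ring. That change gave a 2.3-fold lower number from compound 1 to compound 2 (0.36 log units; beyond the scatter), a step counted as beyond the scatter. Compound 3 carries a different core; how its core differs from that of compound 1 is not broken down here, and compound 3 sits within the scatter of both compound 1 and compound 2, so no order among the three is claimed.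

Compound 4, `COc1cc2c(Nc3cccc(Br)c3)ncnc2cc1OCCOCCn1ccnc1[N+](=O)[O-]`, has not been measured. It stands to compound 3 as compound 2 stands to compound 1: 2-(2-nitro-1H-imidazol-1-yl)ethoxy in place of 3-(2-nitro-1H-imidazol-1-yl)propyl on a saturated chain carbon, two bonds along the chain from an oxygen on an aromatic ring. The place of the change is the same in both pairs, so it is the same change on a second core, though its size has been seen only once.

Among the measured compounds shown here, compound 4 is expected to show a 2.1-fold lower number from compound 3 to compound 4 (0.32 log units; beyond the scatter), resting on the single earlier step of a 2.3-fold lower number from compound 1 to compound 2 (0.36 log units; beyond the scatter) and on compound 3 giving 8420 nM. The estimate for compound 4 in this assay is 4000 nM, ranging from 1800 nM to 9000 nM, since one observation of the step leaves the size uncertain.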

Compound 4, half-maximal inhibitory concentration: 10100 nM
The estimate for compound 4 lay 2.5-fold (0.40 log units) below the measured number, outside the stated range (above it).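

In this assay, putting 2-(2-nitro-1H-imidazol-1-yl)ethoxy in place of 3-(2-nitro-1H-imidazol-1-yl)propyl on the second core gave a 1.2-fold higher number from compound 3 to compound 4 (0.08 log units; within the scatter), so the step seen on the first core did not recur. The two cores did not respond alike to the same change: the same change on two cores in this assay, a 2.3-fold lower number (0.36 log units; beyond the scatter) from compound 1 to compound 2 and a 1.2-fold higher number (0.08 log units; within the scatter) from compound 3 to compound 4, 2.8-fold (0.44 log units) apart, beyond the scatter of two such steps This shows that, in this series, the size of the step on one core cannot simply be carried over to the other, but it does not show why the cores part ways, and with a single pair on each core it cannot say which result is more typical.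

The compounds shown leave open how this change would behave on a third core, so it remains unknown whether the step depends on the core in any regular way. They also leave open whether a longer chain carrying the nitroimidazole, or an amine in its place, would give a clearer difference.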